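The compounds below may be only part of what the source reports. "The series", "measured", "known", "first", "only" and "open" are said of these compounds alone.

Measured so far in a functional assay on MIA PaCa-2 cells (Homo sapiens) for inhibition, read by MTT assay, with a stated time of 3 days; a higher number here means a weaker inhibitor, a lower number a stronger inhibitor:
- Compound 1 `CCN(CC)C(=O)c1ccc(S(=O)(=O)N2CCC[C@@H](C(=O)N3CCN(c4nc(C(C)C)no4)CC3)C2)cc1`: 70 nM
- Compound 2 `CC(C)c1noc(N2CCN(C(=O)[C@@H]3CCCN(S(=O)(=O)c4ccc(S(=O)(=O)NC(C)(C)C)cc4)C3)CC2)n1`: 100 nM

Within the data shown here, compound 2 is not separated from the only other measured compound: the step, a 1.4-fold higher number from compound 1 to compound 2 (0.15 log units; within the scatter), stays within the scatter. Compound 3 `CC(C)NS(=O)(=O)c1ccc(S(=O)(=O)N2CCC[C@@H](C(=O)N3CCN(c4nc(C(C)C)no4)CC3)C2)cc1` changes tert-butyl to isopropyl: hydrogen in place of methyl on a saturated chain carbon bound to two saturated chain carbons and a sulfonamide nitrogen. Among the measured compounds shown here, no measured step covers this exact change. The nearest evidence is that larger replacement from compound 1, which left this assay within the scatter, so no shift beyond the scatter, in either direction, is expected. The expected step is a 1.1-fold lower number from compound 2 to compound 3 (0.05 log units; within the scatter). Compound 3 is estimated at 90 nM, with an expected range of 40 nM to 200 nM.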

Compound 3, half-maximal inhibitory concentration: 200 nM
The estimate for compound 3 lay 2.2-fold (0.35 log units) below the measured number; low and high end bracket the measured number.
By their numbers in this assay, from the lowest: compounds 1, 2 and 3 (each within the scatter of the next, the first and the last beyond it).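

In this assay tert-butyl to isopropyl gives a 2.0-fold higher number from compound 2 to compound 3 (0.30 log units; within the scatter) and so does not separate the pair. Isopropylsulfamoyl in place of diethylcarbamoyl gives a 2.9-fold higher number from compound 1 to compound 3 (0.46 log units; beyond the scatter) and is the first modest separation on this aromatic carbon, one that (tert-butyl)sulfamoyl did not reach. No data shown here explain this result.

Open, from the compounds shown here alone, is how methylsulfamoyl or unsubstituted sulfamoyl would compare with the isopropylsulfamoyl and (tert-butyl)sulfamoyl groups. Also open, going by these compounds, is the outcome with a carboxylic acid or an amine on that aromatic carbon.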